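The compounds below may be only part of what the source reports. "The series", "measured", "known", "first", "only" and "open" are said of these compounds alone.

Measured in a functional assay on A549 cells (Homo sapiens) for antiproliferative activity, read by MTT assay, with a stated time of 72 h; on this read-out lower numbers stand for stronger inhibition and higher numbers for weaker inhibition:
- compound 1 `CC/C=C/C(=O)Nc1cccc(Oc2nc(Nc3cccc(C#N)c3)nc3c2CSCC3)c1`: 10100 nM
- compound 2 `CC(C)=CC(=O)Nc1cccc(Oc2nc(Nc3cccc(C#N)c3)nc3c2CSCC3)c1`: 36900 nM

Compound 2 holds the higher of the two numbers, which makes it the weaker of the pair. Compound 3 `COc1ccc(Nc2nc3c(c(Oc4cccc(NC(=O)C=C(C)C)c4)n2)CSCC3)cn1` keeps the group on the carbonyl carbon of compound 2 and changes the aromatic group on the nitrogen: 6-methoxypyridin-3-yl in place of 3-cyanophenyl on a nitrogen on an aromatic ring.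

Going by the values given here, the only measured step is a 3.7-fold higher number from compound 1 to compound 2 (0.56 log units; beyond the scatter). It lies at the carbonyl end, not at the place where compound 3 differs, so it offers a sense of scale and no direction. Among the compounds with values here, no measured step covers this exchange. In this assay, no change beyond the scatter is therefore expected, with a slight lean towards a lower number. The estimate corresponds to an expected 1.7-fold lower number from compound 2 to compound 3 (0.22 log units; within the scatter). For compound 3 the expected value is 22000 nM, with an estimated range of 7000 nM to 60000 nM.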

Compound 3, half-maximal inhibitory concentration: 16800 nM
Estimate against measurement, compound 3: 1.3-fold (0.12 log units) above; the range from low to high includes it.
By their numbers in this assay, from the lowest: compounds 1 and 3 (each within the scatter of the next); then compound 2.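

In this assay, the group on the nitrogen on an aromatic ring now has a measured effect of its own: 6-methoxypyridin-3-yl in place of 3-cyanophenyl gives a 2.2-fold lower number from compound 2 to compound 3 (0.34 log units; beyond the scatter). Going by these compounds alone, until now, the only measured change lay at the carbonyl end, so this is the first sign that the number also responds at this second place. The exchange alters the ring and its substituent together while the heavy-atom count stays the same, and no available evidence bears on the reason for the shift.

Going by these compounds, it remains open whether the ring nitrogen or the methoxy carries the step, which pyridin-3-yl or 3-methoxyphenyl on that nitrogen would help to separate. Also open, on these data alone, is whether the same exchange gives a step of similar size with but-1-en-1-yl on the carbonyl carbon.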